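Extending the core of compound 1 toward an unmeasured ether

A few compounds are considered here, and "the series" means these few. Any claim that something is new, unique, unknown or untested is made for them only; others in the source may bear on it.

Compound 1 `O/N=C(/Nc1cccc(Cl)c1)c1ccc2occc2c1` is measured in an assay on isolated protein for inhibition of Indoleamine 2,3-dioxygenase 1 (Homo sapiens), read by spectrophotometry (a higher number here means a weaker inhibitor, a lower number a stronger inhibitor), where compound 1 gives 690 nM, the only definite number shown. Compound 2 `O/N=C(/Nc1cccc(COc2ccccc2)c1)c1ccc2occc2c1` reaches only the limit > 30000 nM in this assay. The step of an at least 43-fold higher number from compound 1 to compound 2 (1.63 log units; beyond the scatter) concerns a change at a different place from the one altered here. Compound 3 `O/N=C(/Nc1cccc(Cl)c1)c1ccc2oc(COCC3CC3)cc2c1` differs from compound 1 by (cyclopropylmethoxy)methyl in place of hydrogen on an aromatic carbon. Going by the values given here, no measured step touches this position, so a step no larger than the scatter is expected, as a 1.7-fold higher number from compound 1 to compound 3 (0.24 log units; within the scatter). Compound 3 is therefore estimated at 1200 nM, within 300 nM to 6000 nM.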

Compound 3, half-maximal inhibitory concentration: 1500 nM
Estimate against measurement, compound 3: 1.3-fold (0.10 log units) below; the range from low to high includes it.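

In this assay, (cyclopropylmethoxy)methyl in place of hydrogen, next to the ring oxygen, gives a 2.2-fold higher number from compound 1 to compound 3 (0.34 log units; beyond the scatter). This step is modest, so this position accepts a group of 6 heavy atoms with only a small loss, whereas the earlier step at the chloro position is large: an at least 43-fold higher number from compound 1 to compound 2 (1.63 log units; beyond the scatter). Nothing shown gives a reason for the size of the new step.

With one group at this position, no trend can be read. On these data alone, whether an amine, a carboxylic acid or a simple longer chain here would keep or lose inhibition remains open.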